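A few compounds are considered here, and "the series" means these few. Any claim that something is new, unique, unknown or untested is made for them only; others in the source may bear on it.

In a functional assay on M21 cells (Homo sapiens) for antiproliferative activity, read by sulforhodamine B assay, with a stated time of 48 h (on this read-out higher numbers stand for weaker inhibition and lower numbers for stronger inhibition), compound 3 `CCCNC(=O)Nc1ccc(S(=O)(=O)Oc2ccccc2C(C)C)cc1` gives 5100 nM, the lowest of the three numbers; compound 2 `CC(C)C(=O)Nc1ccc(S(=O)(=O)Oc2ccccc2I)cc1` gives 13000 nM and compound 1 `CC(=O)Nc1ccc(S(=O)(=O)Oc2ccccc2I)cc1` gives 27000 nM. Among the compounds with values here, the only single-site step measured, a 2.1-fold lower number from compound 1 to compound 2 (0.32 log units; beyond the scatter), concerns the acyl group and not the aryl substituent. Compound 4 `CCCNC(=O)Nc1ccc(S(=O)(=O)Oc2ccccc2I)cc1` differs from compound 3 by iodo in place of isopropyl on an aromatic carbon. Within the data shown here, no measured step bears on this exchange, so its size and direction remain unknown from the data; the numbers for compound 2 and compound 1, which carry iodo, sit higher than that of compound 3, but they also differ at the acyl group. Compound 4 is therefore estimated near 7000 nM in this assay, within 2500 nM to 20000 nM, meaning an expected step of a 1.4-fold higher number from compound 3 to compound 4 (0.14 log units; within the scatter).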

Compound 4, half-maximal inhibitory concentration: 5400 nM
Compound 4: the middle estimate sits 1.3-fold (0.11 log units) above what was measured; the range from low to high includes it.
By their numbers in this assay, from the lowest: compounds 3 and 4 (each within the scatter of the next); then compound 2; then compound 1.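

Iodo in place of isopropyl on an aromatic carbon, ortho to a large group, gives a 1.1-fold higher number from compound 3 to compound 4 (0.02 log units; within the scatter) with propylamino held on the carbonyl, so this single exchange leaves the read-out within the scatter. With iodo held fixed, propylamino gives a 2.4-fold lower number from compound 2 to compound 4 (0.38 log units; beyond the scatter) and a 5.0-fold lower number from compound 1 to compound 4 (0.70 log units; beyond the scatter) on the carbonyl carbon, so the lower number of compound 3 goes with propylamino and not with isopropyl. No measurement offers an explanation for either result.

The iodo and isopropyl comparison rests on one pair. As far as these compounds go, how methoxy or a carboxylic acid would behave on that aromatic carbon, or a longer chain in place of propylamino, stays open.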